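This account rests on a few compounds, and the source may have more. Where it says the series, first, only, none or still open, it means among the compounds named here.

Compound 1 `CCCCC(N)c1cc(C(F)(F)F)ccc1N1CCN(C(=O)CCc2ccc(Cl)cc2Cl)CC1` stands lowest of the three measured numbers in an assay on HEK293 cells for displacement of a labelled ligand from Melanocortin receptor 4 (Homo sapiens); a higher number here means a weaker inhibitor, a lower number a stronger inhibitor: compound 1 gives 190 nM. Compound 2 `COc1ccc(CCC(=O)N2CCN(c3ccc(C(F)(F)F)cc3[C@@H](N)CC(C)C)CC2)cc1` gives 350 nM in this assay, which lies within the scatter of compound 1, so no order between the two can be read. Compound 3 `COc1ccc(OC)c(CCC(=O)N2CCN(c3ccc(C(F)(F)F)cc3[C@@H](N)CC(C)C)CC2)c1` gives 2500 nM in this assay, a gap from compound 1 that lies beyond the scatter. For the measured compounds named here, the only measured step, a 7.1-fold higher number from compound 2 to compound 3 (0.85 log units; beyond the scatter), concerns the chain end of the shared core, the aromatic group two bonds along the chain from a carbonyl carbon.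

Compound 4 `CCC(C)[C@H](NC(C)=O)c1cc(C(F)(F)F)ccc1N1CCN(C(=O)CCc2ccc(Cl)cc2Cl)CC1` differs from compound 1 in one place: 1-acetamido-2-methylbutyl in place of 1-aminopentyl on an aromatic carbon. Going by the values given here, no measured step touches this position, so the measured compounds give no direction for the change, and the expectation rests on the structural change alone with a wide range. Compound 4 is estimated to give 500 nM in this assay, expected between 100 nM and 3000 nM, which means an expected step of a 2.6-fold higher number from compound 1 to compound 4 (0.42 log units; beyond the scatter).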

Compound 4, inhibition constant: 360 nM
Compound 4: the middle estimate sits 1.4-fold (0.14 log units) above what was measured; the range from low to high includes it.
By their numbers in this assay, from the lowest: compounds 1, 2 and 4 (each within the scatter of the next); then compound 3.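

In this assay, for the compounds shown here, the step of a 1.9-fold higher number from compound 1 to compound 4 (0.28 log units; within the scatter) is the first reading at this position, and it shows that 1-acetamido-2-methylbutyl can stand in place of 1-aminopentyl on the core of compound 1 without a change that can be read. The entering group has 9 heavy atoms against 6 and carries its nitrogen as an acetamide, so for this pair a free amino group on the chain is not needed to stay within the scatter. Nothing available explains this result.

On these data alone, since the acetyl group and the branched chain enter together, their separate contributions remain open, and a 1-acetamidopentyl or a 1-amino-2-methylbutyl group would separate them. Also open, as far as these compounds go, is how a methanesulfonamide or a carboxylic acid would read at this position.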